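This account rests on a few compounds, and the source may have more. Where it says the series, first, only, none or still open, it means among the compounds named here.

Compound 1 `Cn1ncc2cc(-c3cnccc3/C=C/C(=O)O)ccc21` is measured in a functional assay on KB cells (Homo sapiens) for inhibition, read by sulforhodamine B assay, with a stated time of 72 h (on this read-out lower numbers stand for stronger inhibition of growth and higher numbers for weaker inhibition of growth), where compound 1 reaches only the limit of > 10000 nM. Compound 2 `Cn1ccc2cc(-c3cnccc3/C=C/C(=O)O)ccc21` also gives just a limit in this assay, > 10000 nM. How the core of compound 1 differs from the core of compound 2 is not broken down here. Compound 3 `CNC(=O)/C=C/c1ccncc1-c1ccc2c(ccn2C)c1` gives 7080 nM in this assay; the change from compound 2 to compound 3 is methylamino in place of hydroxy on a carbonyl carbon, and it made an at least 1.4-fold lower number from compound 2 to compound 3 (0.14 log units; that floor lies within the scatter), a step bounded by the limit of > 10000 nM in this assay, at which 2 of the 3 values shown sit. Compound 4 `CNC(=O)/C=C/c1ccncc1-c1ccc2c(cnn2C)c1` is not yet measured; it differs from compound 1 by the same change, (methylamino in place of hydroxy on a carbonyl carbon). Since compound 1 shows only a limit, the step is expected to be about an at least 1.2-fold lower number from compound 1 to compound 4 (0.09 log units; that floor lies within the scatter), resting on the measured step from compound 2 to compound 3 an at least 1.4-fold lower number from compound 2 to compound 3 (0.14 log units; that floor lies within the scatter). For compound 4 in this assay the estimate is 8000 nM, between 3000 nM and 30000 nM.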

Compound 4, concentration for 50% growth inhibition: > 10000 nM
Compound 4 ended at the assay's limit; the forecaster's own chance of this, stated with the estimate: 45%; middle value at least 1.2-fold (0.09 log units) away from the limit.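

Compound 1 and compound 4 both sit at a limit in this assay, so the step between them cannot be read: the limit of > 10000 nM in this assay, at which 3 of the 4 values shown sit.

The compounds shown leave open how far methylamino in place of hydroxy on a carbonyl carbon shifts growth inhibition on the core of compound 1.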